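This account rests on a few compounds, and the source may have more. Where it says the series, first, only, none or still open, it means among the compounds named here.

Measured compounds:
Compound 1 `COc1cc(NC(C)CCCNC(=O)NN)c2ncccc2c1`: >= 250000 nM
Compound 2 `CCOC(=O)NC(c1ccccc1)c1ccc(Cl)cc1`: > 250000 nM

Both results come from a functional assay on HeLa cells (Homo sapiens) for inhibition, read by MTT assay, with a stated time of 4 days; on this read-out lower numbers stand for stronger inhibition and higher numbers for weaker inhibition. Compound 1 stands at >= 250000 nM, which is a limit of the assay and not a number. Compound 2 gives > 250000 nM, which is also a limit. For the measured compounds named here, neither compound therefore has an exact value, and no measured step is available as a guide.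

Compound 3 `COc1cc(NC(C)CCCNC(=O)NNC(=O)N(CCO)CCO)c2ncccc2c1` keeps the core of compound 1 but carries bis(2-hydroxyethyl)carbamoyl in place of hydrogen on an amine nitrogen. Going by the values given here, the only starting point is compound 1 at >= 250000 nM, so a large gain in this assay is not expected. The expected at least 1.6-fold lower number from compound 1 to compound 3 (0.22 log units; that floor lies within the scatter) is small and towards stronger inhibition, and it may not exceed the scatter. For compound 3 the estimated value is 150000 nM, with an expected range from 40000 nM to 250000 nM.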

Compound 3, half-maximal inhibitory concentration: > 250000 nM
Compound 3: a limit, no number; the forecaster's own chance of this, stated with the estimate: 55%; middle value at least 1.6-fold (0.22 log units) from the limit.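

Compound 1 and compound 3 both give limits in this assay, not numbers, and the step between them cannot be read. The compounds shown leave open whether bis(2-hydroxyethyl)carbamoyl in place of hydrogen on this amine nitrogen changes inhibition at all.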